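The source may report more compounds than this note shows. Statements on the series, on what has been measured and on what is new or still open speak of the compounds shown alone.

Measured compounds:
Compound 1, `O=C(/C=C/c1ccc(O)c(O)c1)c1ccc2occc2c1O`: in an assay on isolated protein for inhibition of lysosomal alpha-glucosidase (Rattus norvegicus), read by spectrophotometry, with a stated time of 5 min, tested at 25 ug/mL (a higher number here means more inhibition at the concentration tested (going by the name of the read-out), a lower number less inhibition), compound 1 gives 61.5%.
Compound 2, `COc1ccc(/C=C/C(=O)c2cc3ccoc3cc2O)cc1`: compound 2 gives 48.9%.
Compound 3, `O=C(/C=C/c1ccc(O)cc1)c1cc2ccoc2cc1O`: compound 3 gives 8.77%.

Compound 1 stands highest of the three, with its steps to compound 2 and to compound 3 both beyond the scatter. The step of a number 40.1 percentage points higher from compound 3 to compound 2 (beyond the scatter) goes with one change, (methyl in place of hydrogen on an oxygen on an aromatic ring). The unmeasured compound 4, `COc1cc(/C=C/C(=O)c2ccc3occc3c2O)ccc1O`, carries the same change on the core of compound 1: methyl in place of hydrogen on an oxygen on an aromatic ring. The place lines of the two changes read the same word for word. How the cores of compound 1 and compound 3 differ is not broken down here. Since the earlier step of a number 40.1 percentage points higher from compound 3 to compound 2 (beyond the scatter) was large and lifted inhibition, a rise is expected from compound 1 to compound 4 as well, though smaller, because compound 1 already gives 61.5%; the expected step is a number 6.5 percentage points higher from compound 1 to compound 4 (within the scatter). Compound 4 is estimated at 68%, between 45% and 88%.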

Compound 4, a percentage reported as inhibition, at one concentration (the size of the read-out at that concentration, not a potency): 45%
Compound 4: middle estimate off by 23 percentage points, on the high side, within the range that was stated.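

Methyl in place of hydrogen on an oxygen on an aromatic ring gave a number 16.5 percentage points lower from compound 1 to compound 4 (beyond the scatter), so the large rise seen on the other core did not carry over to the core of compound 1. The same change therefore moved inhibition in opposite directions on the two cores in this assay: the same change on two cores in this assay, a number 40.1 percentage points higher (beyond the scatter) from compound 3 to compound 2 and a number 16.5 percentage points lower (beyond the scatter) from compound 1 to compound 4, 56.6 percentage points apart, beyond the scatter of two such steps. These two pairs show that the step cannot be transferred from one of these cores to the other, but they do not show which difference between the cores matters or what the change would do on a third core.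

The compounds shown leave open how a longer chain on that oxygen, such as ethoxy, would behave on either core. They also leave open what an amine in place of the hydroxy would do.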